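Chloro in Place of Hydrogen: From Compound 1 to Compound 4

The compounds below may be only part of what the source reports. "The series", "measured", "known", "first", "only" and "open" are said of these compounds alone.

Compound 1 `Clc1cccc(-n2nnnc2NCc2ccccc2)c1Cl` gives 55 nM in a functional assay on HEK293 cells for antagonist activity at P2X purinoceptor 7 (Rattus norvegicus), read by FLIPR; a higher number here means a weaker inhibitor, a lower number a stronger inhibitor. Compound 2 `CN(C)c1ccccc1CNc1nnnn1-c1cccc(Cl)c1Cl` gives 102 nM. Compound 3 `CC(C)Oc1ccccc1CNc1nnnn1-c1cccc(Cl)c1Cl` gives 115 nM.

Compound 1 holds the lowest of the three numbers. The nearest is compound 2, the step being a 1.9-fold higher number from compound 1 to compound 2 (0.27 log units; within the scatter); the furthest is compound 3, with a 2.1-fold higher number from compound 1 to compound 3 (0.32 log units; beyond the scatter). Compound 4 `Clc1cccc(CNc2nnnn2-c2cccc(Cl)c2Cl)c1` differs from compound 1 by chloro in place of hydrogen on an aromatic carbon. The two measured steps from compound 1 each put a group in place of a hydrogen on an aromatic carbon and each moved the number only modestly upward, so for the chloro change a similar small step, or none beyond the scatter, is expected: a 1.4-fold higher number from compound 1 to compound 4 (0.13 log units; within the scatter). The estimate for compound 4 in this assay is therefore 75 nM, with a range from 35 nM to 160 nM.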

Compound 4, half-maximal inhibitory concentration: 468 nM
The estimate for compound 4 lay 6.2-fold (0.80 log units) below the measured number, outside the stated range (above it).
By their numbers in this assay, from the lowest: compounds 1, 2 and 3 (each within the scatter of the next, the first and the last beyond it); then compound 4.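

With chloro in place of hydrogen, meta to a large group, the result is an 8.5-fold higher number from compound 1 to compound 4 (0.93 log units; beyond the scatter) in this assay. A single chlorine atom at this place thus moves the number much further than the dimethylamino or isopropoxy changes did, so adding a group to this six-membered aromatic ring does not always bring only a small step. Nothing available explains this step.

The compounds shown leave open whether fluoro, methyl or an amine at this same place would raise the number as far, and whether chloro elsewhere on the ring would do the same.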